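The source may report more compounds than this note shows. Statements on the series, on what has been measured and on what is new or still open speak of the compounds shown alone.

In a functional assay on HeLa cells (Homo sapiens) for cytotoxicity, read by sulforhodamine B assay (a higher number here means a weaker inhibitor, a lower number a stronger inhibitor), compound 1 `COc1ccc(N(C)c2nc(C)nc3ccccc23)cc1` gives 2 nM. Compound 3 `COc1ccc(N(C)c2ncnc3ccccc23)cc1` differs from compound 1 by hydrogen in place of methyl on an aromatic carbon; in this assay compound 3 gives 8.6 nM. The change made a 4.3-fold higher number from compound 1 to compound 3 (0.63 log units; beyond the scatter). Compound 2 `COc1ccc2c(c1)CCCN2c1nc(C)nc2ccccc12` carries a different core; how the two cores differ is not broken down here. In this assay compound 2 gives 1.2 nM, which lies within the scatter of the number for compound 1. Among the compounds with values here, compound 4 `COc1ccc2c(c1)CCCN2c1ncnc2ccccc12` has not yet been measured; it differs from compound 2 by hydrogen in place of methyl on an aromatic carbon, the same change at the same place as the one from compound 1 to compound 3. The step from compound 2 to compound 4 in this assay is expected to be a 4.2-fold higher number from compound 2 to compound 4 (0.62 log units; beyond the scatter), resting on a 4.3-fold higher number from compound 1 to compound 3 (0.63 log units; beyond the scatter). Compound 4 is therefore estimated at 5 nM, with the expected range from 2 nM to 12 nM.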

Compound 4, half-maximal inhibitory concentration: 16.8 nM
Beside the measured number, compound 4's estimate is 3.4-fold (0.53 log units) below it, and the stated range ends below it.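

Swapping the methyl for hydrogen raises the number on both cores in this assay, so the direction of the change carries over, and the new step reads a 14-fold higher number from compound 2 to compound 4 (1.15 log units; beyond the scatter). Within the data shown here, the size of the change, however, does not carry over from one core to the other: the same change on two cores in this assay, a 4.3-fold higher number (0.63 log units; beyond the scatter) from compound 1 to compound 3 and a 14-fold higher number (1.15 log units; beyond the scatter) from compound 2 to compound 4, 3.3-fold (0.51 log units) apart, beyond the scatter of two such steps With only one such pair on each core, these numbers do not show why the two cores respond differently, or whether the same gap would appear with any other change.

The compounds shown leave open how an ethyl group, an amine or a chlorine atom would behave at this place, between two ring nitrogen atoms. As far as these compounds go, it also remains open whether any of these would match methyl on either core.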